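Selenium-Benzyl for Methylsulfanyl on Two Different Cores

A few compounds are considered here, and "the series" means these few. Any claim that something is new, unique, unknown or untested is made for them only; others in the source may bear on it.

Compound 1 `CS/C(=N\C(=O)c1csc([N+](=O)[O-])c1)NC(=O)c1csc([N+](=O)[O-])c1` gives > 100000 nM in a functional assay on HepG2 cells (Homo sapiens) for cytotoxicity, read by MTT assay, with a stated time of 72 h; a lower number here means a stronger inhibitor of growth, a higher number a weaker inhibitor of growth; that is a limit of the assay, not a number.
Compound 2 `O=C(/N=C(/NC(=O)c1csc([N+](=O)[O-])c1)[Se]Cc1ccccc1)c1csc([N+](=O)[O-])c1` gives 62800 nM in this assay.
Compound 3 `CS/C(=N\C(=O)c1cnc2ccccc2c1)NC(=O)c1cnc2ccccc2c1` gives > 100000 nM in this assay; that is a limit of the assay, not a number.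

Compound 2 differs from compound 1 by a group of 8 heavy atoms (7 carbon, 1 selenium; one six-membered aromatic ring of carbon only) in place of a group of 2 heavy atoms (1 carbon, 1 sulfur; no ring), on a carbon with a double bond to nitrogen. This gave an at least 1.5-fold lower number from compound 1 to compound 2 (0.20 log units; that floor lies within the scatter). How far the number truly fell is open, since compound 1 sits at the limit of > 100000 nM in this assay, at which 2 of the 3 values shown sit.

Compound 4 `O=C(/N=C(/NC(=O)c1cnc2ccccc2c1)[Se]Cc1ccccc1)c1cnc2ccccc2c1` differs from compound 3 by a group of 8 heavy atoms (7 carbon, 1 selenium; one six-membered aromatic ring of carbon only) in place of a group of 2 heavy atoms (1 carbon, 1 sulfur; no ring), on a carbon with a double bond to nitrogen, the same change on another core; the difference between the two cores is not broken down here. Since compound 3 also sits at the limit of > 100000 nM in this assay, at which 2 of the 3 values shown sit, a similar move of an at least 1.4-fold lower number from compound 3 to compound 4 (0.15 log units; that floor lies within the scatter) is expected in this assay. For compound 4 the estimate is 70000 nM, with a range from 30000 nM to 150000 nM, and a fair chance that only a limit is reported.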

Compound 4, concentration for total growth inhibition: 48900 nM
The estimate for compound 4 lay 1.4-fold (0.16 log units) above the measured number; the range from low to high includes it.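

Putting the selenium-benzyl group in place of methylsulfanyl gave an at least 2.0-fold lower number from compound 3 to compound 4 (0.31 log units; beyond the scatter) in this assay. The change therefore points the same way on both cores, although only the second step is beyond the scatter: the same change on two cores in this assay, an at least 1.5-fold lower number (0.20 log units; that floor lies within the scatter) from compound 1 to compound 2 and an at least 2.0-fold lower number (0.31 log units; beyond the scatter) from compound 3 to compound 4; the limit leaves it open whether they differ It does not show how large either step truly is, or that the change would carry to any further core, since each starting compound stands at a limit of the assay and not at a number: the limit of > 100000 nM in this assay, at which 2 of the 4 values shown sit.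

Going by these compounds, the change swaps the sulfur for selenium and the methyl for a benzyl group together, so it remains open which of the two matters. On these data alone, a benzylsulfanyl or methylselanyl group on the same carbon would separate them, and how an amine there would behave is also open.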